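A few compounds are considered here, and "the series" means these few. Any claim that something is new, unique, unknown or untested is made for them only; others in the source may bear on it.

Of the compounds shown here, two sharing one core have been measured in a functional assay on HeLa cells (Homo sapiens) for cytotoxicity, read by sulforhodamine B assay; on this read-out higher numbers stand for weaker inhibition and lower numbers for stronger inhibition. In this assay, compound 1 `Cc1ccc(S(=O)(=O)NC(C2=CC(=O)c3c(O)ccc(O)c3C2=O)C(C)C)cc1` gives 4850 nM and compound 2 `CC(C)C(NS(=O)(=O)c1cccc(Br)c1)C1=CC(=O)c2c(O)ccc(O)c2C1=O` gives 860 nM, the lower of the two numbers and so the stronger inhibition of the pair. Compound 3 `CC(C)C(NS(=O)(=O)c1ccccc1Br)C1=CC(=O)c2c(O)ccc(O)c2C1=O` has the same atoms as compound 2, joined differently: 2-bromophenyl stands in place of 3-bromophenyl on a sulfonyl sulfur (2-bromophenyl in place of 3-bromophenyl on a sulfonyl sulfur).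

Within the data shown here, only one measured step bears on this change: a 5.6-fold lower number from compound 1 to compound 2 (0.75 log units; beyond the scatter). This modest step, beyond the scatter, put 3-bromophenyl in place of 4-methylphenyl on a sulfonyl sulfur. It replaced one group with a different one, whereas compound 3 keeps the same kind of group. Among the measured compounds shown here, no measured pair shows what this change alone does, so the direction stays open, and a step smaller than that one is expected, with none beyond the scatter as the most likely outcome. The estimated change is a 1.3-fold higher number from compound 2 to compound 3 (0.11 log units; within the scatter). For compound 3, the expected value is 1100 nM, with an estimated range from 350 nM to 3000 nM.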

Compound 3, half-maximal inhibitory concentration: 8310 nM
For compound 3 the middle estimate is 7.6-fold (0.88 log units) below the measured one; the whole stated range lies below it.
By their numbers in this assay, from the lowest: compound 2; then compounds 1 and 3 (each within the scatter of the next).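

In this assay, the two bromophenyl groups on the sulfonyl sulfur are not interchangeable, even though they contain the same atoms: 2-bromophenyl in place of 3-bromophenyl gives a step beyond the scatter (a 9.7-fold higher number from compound 2 to compound 3 (0.99 log units; beyond the scatter)), so the low number of compound 2 does not follow from having a bromophenyl group alone. Putting 2-bromophenyl in place of 4-methylphenyl gives a step within the scatter (a 1.7-fold higher number from compound 1 to compound 3 (0.23 log units; within the scatter)), so among these three compounds only the 3-bromophenyl group stands apart, with compound 1 and compound 3 level within the usual variation. No measurement here explains why the two bromophenyl groups differ.

These three compounds cannot show whether it is the bromine itself that matters in the 3-bromophenyl group, which a 3-chlorophenyl or 3-methoxyphenyl group on the same sulfur would help to test. On these data alone, how an unsubstituted phenyl or a 4-bromophenyl group would compare also remains open, and either would show how the numbers run across the full set of ring patterns.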